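Nitro position on the sulfonyl ester: compound 4 expected

The compounds below may be only part of what the source reports. "The series", "measured", "known", "first", "only" and "open" are said of these compounds alone.

Four cyanoacrylamides bearing a sulfonylated phenol share the thiadiazole amide core. Compound 1 `COc1ccc(Cc2nnc(NC(=O)/C(C#N)=C/c3ccccc3OS(=O)(=O)c3ccc([N+](=O)[O-])cc3)s2)cc1` and compound 2 `COc1ccc(Cc2nnc(NC(=O)/C(C#N)=C/c3ccccc3OS(=O)(=O)c3ccccc3[N+](=O)[O-])s2)cc1` carry a methoxy on the benzyl ring; compound 3 `N#C/C(=C\c1ccccc1OS(=O)(=O)c1ccc([N+](=O)[O-])cc1)C(=O)Nc1nnc(Cc2ccccc2)s1` and compound 4 `N#C/C(=C\c1ccccc1OS(=O)(=O)c1ccccc1[N+](=O)[O-])C(=O)Nc1nnc(Cc2ccccc2)s1` lack it. The core of compound 1 and the core of compound 3 differ by hydrogen in place of methoxy on an aromatic carbon.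

In an ADME assay on HEK-293T cells (Homo sapiens) for inhibition, read by CCK-8 assay, with a stated time of 48 h, tested at 20 uM (on this read-out higher numbers stand for more inhibition of growth at the one concentration tested and lower numbers for less inhibition of growth), compound 1 gives 17%. In this assay compound 2 gives 18%. The step of a number 1 percentage points higher from compound 1 to compound 2 (within the scatter) goes with the change (2-nitrophenyl in place of 4-nitrophenyl on a sulfonyl sulfur). Compound 3 is reported in this assay as "not toxic" (no number reported), so no number stands for it.

The change from compound 3 to compound 4 is 2-nitrophenyl in place of 4-nitrophenyl on a sulfonyl sulfur. The two place lines read the same, so this is the same change as between compound 1 and compound 2, repeated on a core without the methoxy; it occurs twice in all among these compounds. Because a number 1 percentage points higher from compound 1 to compound 2 (within the scatter) lies within the scatter, the same change on compound 3 is expected to make a step of similar size, that is, none that can be told from repeated measurement. With no number for compound 3, only its report of no toxicity and the low readings of compound 1 and compound 2 anchor the expectation. Compound 4 is expected to give 12% in this assay, with a range of 0% to 25%, and a fair chance that again no number is reported.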

Compound 4, percent growth inhibition at one concentration: 10%
Compound 4: middle estimate off by 2 percentage points, on the high side; the measured number falls inside the stated range.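

In this assay there is a number 8 percentage points lower from compound 2 to compound 4 (within the scatter) with hydrogen in place of methoxy on an aromatic carbon, so among the compounds carrying the 2-nitrophenyl group, loss of the methoxy gives no difference that can be told from repeated measurement. The change of 2-nitrophenyl in place of 4-nitrophenyl on a sulfonyl sulfur can be read only on the methoxy core, as a number 1 percentage points higher from compound 1 to compound 2 (within the scatter) and not on the core without methoxy; compound 3 has only the report "not toxic" and no number, so the steps that involve it cannot be read, and the reading for compound 4 does not show that the change carries from one core to the other. No measurement is at hand that bears on the reason for these readings.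

The compounds shown vary only in the place of the nitro group and in the presence of the methoxy, so it stays open how this assay would read with an amine or a carboxylic acid in place of that methoxy. As far as these compounds go, it also stays open what a longer chain in place of the nitrophenyl group on the sulfonyl sulfur would give.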